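The source may hold more compounds than are shown below. What is called first, only, known or untested is meant among the compounds shown, and "the series" means these compounds.

Three closely related compounds have been tested in an ADME assay on RD cells (Homo sapiens) for cytotoxicity, read by MTT assay, with a stated time of 3 days; on this read-out lower numbers stand for higher toxicity in this test and higher numbers for lower toxicity in this test. Compound 1 `CCC[C@@H](CCn1cncn1)c1ccc(F)cc1` gives 56.9 ug/mL, compound 2 `CCC[C@@H](CCn1cncn1)c1ccc(Cl)cc1` gives 40.8 ug/mL, and compound 3 `CCC[C@@H](CCn1cncn1)c1ccc(C)cc1` gives 74.1 ug/mL. These three differ only in the group on the aromatic ring, and the steps between them are small: a 1.4-fold lower number from compound 1 to compound 2 (0.14 log units; within the scatter), a 1.3-fold higher number from compound 1 to compound 3 (0.11 log units; within the scatter), and a 1.8-fold higher number from compound 2 to compound 3 (0.26 log units; within the scatter). Compound 2 has the lowest of the three numbers, yet its gaps to compound 1 and to compound 3 both lie within the scatter, so no real separation among the three can be read from these data.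

Compound 4 `CCCC[C@@H](CCn1cncn1)c1ccc(Cl)cc1` has not yet been measured. It differs from compound 2 in one place: methyl in place of hydrogen on a saturated chain carbon, four bonds along the chain from an aromatic carbon. Going by the values given here, none of the measured steps touches the chain; all three exchange the group on the aromatic carbon, and all three stayed within the scatter. Among the compounds with values here, there is therefore no measured step that bears directly on the change from compound 2 to compound 4, and the measured steps show no large movements in this assay within this small set. The expectation is that compound 4 shows a 1.0-fold lower number from compound 2 to compound 4 (0.01 log units; within the scatter), a change no larger than the scatter. Compound 4 is estimated at 40 ug/mL, with a range from 20 ug/mL to 80 ug/mL.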

Compound 4, half-maximal cytotoxic concentration: 18.7 ug/mL
Beside the measured number, compound 4's estimate is 2.1-fold (0.33 log units) above it, outside the stated range (below it).
By their numbers in this assay, from the lowest: compound 4; then compounds 2, 1 and 3 (each within the scatter of the next).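

The earlier compounds shown here exchanged only the group on the aromatic carbon, and none of those exchanges moved the number in this assay beyond the scatter. This first change on the saturated chain does: methyl in place of hydrogen, four bonds along the chain from an aromatic carbon, turns the propyl chain into a butyl chain and gives a 2.2-fold lower number from compound 2 to compound 4 (0.34 log units; beyond the scatter) in this assay, a modest step towards higher toxicity in this test that shows this position can respond to the addition of a single carbon. No measurement shown here gives a reason for this shift, so the step stands as an observation without an explanation.

The compounds shown leave open whether the number would keep falling with a longer chain such as pentyl or would rise with a shorter one such as ethyl, and whether a hydroxyl group or an amine at the end of the chain would behave like the added methyl. They also leave open whether the same chain change would have a similar effect with fluoro or methyl in place of chloro on the aromatic carbon.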